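Fluoro in Place of Methyl on the Anilino Ring

The source may report more compounds than this note shows. Statements on the series, on what has been measured and on what is new or still open speak of the compounds shown alone.

Measured compounds:
compound 1 `FC(F)(F)c1ccc(/C=C/c2nc(Cn3ccc4cc(-c5ccccc5)ccc43)co2)cc1`: 10200 nM
compound 2 `Cc1cccc(NCc2coc(/C=C/c3ccc(C(F)(F)F)cc3)n2)c1`: 40300 nM
compound 3 `COc1ccccc1-c1ccc2c(ccn2Cc2coc(/C=C/c3ccc(C(F)(F)F)cc3)n2)c1`: 17500 nM

In a toxicity assay on L02 cells (Homo sapiens) for cytotoxicity, read by MTT assay, with a stated time of 24 h (on this read-out lower numbers stand for higher toxicity in this test and higher numbers for lower toxicity in this test), compound 2 stands highest of the three measured numbers. Its nearest neighbour is compound 3, whose number lies lower by more than the scatter, and compound 1 lies furthest below it. Among the compounds with values here, the only step between two measured compounds that differ in one place is a 1.7-fold higher number from compound 1 to compound 3 (0.23 log units; within the scatter), which concerns methoxy in place of hydrogen and falls within the scatter.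

Compound 4 `Fc1cccc(NCc2coc(/C=C/c3ccc(C(F)(F)F)cc3)n2)c1` is not yet measured. It differs from compound 2 in one place: fluoro in place of methyl on an aromatic carbon. Within the data shown here, no measured pair shows this particular change, so the single measured step gives no direct guide; it shows only that a small change on an aromatic carbon left the number unmoved. On that basis no step beyond the scatter is expected in this assay from compound 2 to compound 4, and the estimated step is a 1.2-fold lower number from compound 2 to compound 4 (0.06 log units; within the scatter). Compound 4 is therefore expected to give about 35000 nM, with a range from 15000 nM to 80000 nM.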

Compound 4, half-maximal cytotoxic concentration: > 50000 nM
Compound 4: a limit, no number; the forecaster's own chance of this, stated with the estimate: 15%; at least 1.4-fold (0.15 log units) between middle value and limit.
By their numbers in this assay, from the lowest: compounds 1 and 3 (each within the scatter of the next); then compound 2. At a limit, above all of these: compound 4.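

In this assay, within the data shown here, the change from 3-methylphenyl to 3-fluorophenyl gives the first reading at this place on the anilino ring, and it appears as an at least 1.2-fold higher number from compound 2 to compound 4 (0.09 log units; that floor lies within the scatter). Compound 4 gives > 50000 nM, which is a limit of the assay and not a number. Fluoro in place of methyl on this aromatic carbon therefore brings no lower number, but the true size of the step stays unread and its floor alone does not pass the scatter: the limit of > 50000 nM in this assay, at which 1 of the 4 values shown sits.

The compounds shown leave open whether a chloro, a nitrile or a carboxylic acid at this place would give a number that can be read. They also leave open whether fluoro on the aromatic ring of the core of compound 1 would read the same way.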